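A few compounds are considered here, and "the series" means these few. Any claim that something is new, unique, unknown or untested is made for them only; others in the source may bear on it.

Measured so far:
compound 1 `Cc1cccc(/C(N)=N/NC(=S)N2CCSCC2)n1` — 7.3%
compound 2 `Cc1ccnc(/C(N)=N/NC(=S)N2CCN(c3ccccn3)CC2)c1` — 21%

In a functional assay on MCF7 cells (Homo sapiens) for cytotoxicity, read by MTT assay, with a stated time of 72 h, tested at 1 uM (a lower number here means less inhibition of growth, a higher number more inhibition of growth at the concentration tested), compound 1 gives 7.3%, the lowest of the two numbers. Compound 2 gives 21%, a number higher than that of compound 1 by more than the usual scatter. Compound 3 `N/C(=N\NC(=S)N1CCSCC1)c1ccccn1` differs from compound 1 by hydrogen in place of methyl on an aromatic carbon — hydrogen in place of methyl on an aromatic carbon. Within the data shown here, no step of this kind has yet been measured. In this assay the change is expected to be small, none beyond the scatter, so a step of a number 0.7 percentage points higher from compound 1 to compound 3 (within the scatter) is expected. Compound 3 is estimated at 8%, with a range from 0% to 20%.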

Compound 3, percent growth inhibition at one concentration: 16.3%
For compound 3 the middle estimate is 8.3 percentage points below the measured one, and the stated range covers the measured number.
By their numbers in this assay, from the lowest: compounds 1, 3 and 2 (each within the scatter of the next, the first and the last beyond it).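

In this assay, hydrogen in place of methyl on an aromatic carbon next to the ring nitrogen gives a number 9 percentage points higher from compound 1 to compound 3 (within the scatter), the first step read at this position. The methyl can therefore go without a shift beyond the scatter, and compound 1 and compound 3 cannot be told apart here. No evidence at hand bears on what lies behind this step. Open, on these data alone, is whether an amine or a methoxy group at this position would move the number beyond the scatter. Also open, as far as these compounds go, is whether the same exchange reads alike on compound 2.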